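The source may report more compounds than this note shows. Statements on the series, on what has been measured and on what is new or still open speak of the compounds shown alone.

In a functional assay on cells (Homo sapiens) for cytotoxicity, read by MTT assay, with a stated time of 48 h (a higher number here means a weaker inhibitor, a lower number a stronger inhibitor), compound 1 `CN(CC(=O)Nc1ccccc1O)c1ccccc1` gives > 100000 nM, and this value is a limit of the assay rather than a number. Among the compounds with values here, compound 2 `O=C(CO)Nc1cc(O)ccc1O` gives 12000 nM, which makes it the only compound so far with an actual number in this assay. Within the data shown here, with just this one number and one limit, no comparison between measured compounds can be sized, and no measured step between close relatives is available as a guide.

Compound 3 `O=C(COc1ccccc1)Nc1cc(O)ccc1O` is built directly on compound 2, with phenyl in place of hydrogen on an oxygen on a saturated carbon. The rest of the structure stays the same, so the expectation is anchored on compound 2 and its 12000 nM. The data offer no measurement of what this exchange does, so only a small shift towards stronger inhibition is expected, and no step beyond the scatter. The expected step is a 1.5-fold lower number from compound 2 to compound 3 (0.18 log units; within the scatter). For compound 3 the estimated value is 8000 nM, with an expected range from 2500 nM to 30000 nM.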

Compound 3, half-maximal inhibitory concentration: 3000 nM
Beside the measured number, compound 3's estimate is 2.7-fold (0.43 log units) above it; low and high end bracket the measured number.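

In this assay, within the data shown here, the exchange of hydrogen for phenyl on an oxygen on a saturated carbon gives the first measured step, a 4.0-fold lower number from compound 2 to compound 3 (0.60 log units; beyond the scatter), and this step lies beyond the usual scatter. It shows that this oxygen can carry phenyl, a group of six carbon atoms in one aromatic ring, and that the number then falls rather than rises, which compound 2 alone could not show. The size of the step is modest, and nothing in the data gives a reason for it.

This single step cannot say whether the lower number belongs to the aromatic ring itself or would follow from any group placed on that oxygen, so a small methyl, a longer chain or a benzyl group on the same oxygen would be needed to separate these readings. It also leaves open how far phenyl can be built on, for example with a chlorine, a methoxy group or an amine on the ring, and whether the shared core would respond in the same way elsewhere.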